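Sulfonamide anilides: ring swap on the carbonyl carbon

The source may hold more compounds than are shown below. What is called first, only, known or untested is meant among the compounds shown, and "the series" means these compounds.

The series is built on an amide whose carbonyl bears an aromatic ring. Within the data shown here, compound 1 `N#Cc1ccc(C(=O)Nc2ccc(S(=O)(=O)Nc3ccccc3)cc2)c(F)c1` is the only member with a number so far. In a functional assay on HEK293 cells for agonist activity at probable G-protein coupled receptor 27 (Homo sapiens), read by a luciferase reporter and beta-arrestin recruitment, with a stated time of 10 min (on this read-out lower numbers stand for smaller maximal responses and higher numbers for larger maximal responses), compound 1 gives 29%, a partial maximal response and the sole reference point in the series. Compound 2 `O=C(Nc1ccccc1)c1ccc(NC(=O)c2ccc(Cl)cc2Cl)cc1` belongs to the set but in this assay compound 2 is recorded as "not determined" (no result reported), so no comparison of numbers between compound 1 and compound 2 is possible.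

Compound 3 `O=C(Nc1ccc(S(=O)(=O)Nc2ccccc2)cc1)c1ccc(Cl)nc1F` has not been run in this assay. Against compound 1 the difference is 6-chloro-2-fluoropyridin-3-yl in place of 4-cyano-2-fluorophenyl on a carbonyl carbon; the rest of the shared core is unchanged.

Among the measured compounds shown here, no step between two measured compounds is available, so there is no precedent for what such a ring swap does here. The expectation is therefore a step from compound 1 to compound 3 of a number 1 percentage points lower from compound 1 to compound 3 (within the scatter), which is within the scatter rather than a real move in either direction. Compound 3 is estimated to reach 28% in this assay, with a range from 10% to 50%.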

Compound 3, largest response reached (Emax), in percent of the reference or control that the assay uses: 78%
For compound 3 the middle estimate is 50 percentage points below the measured one, and the stated range ends below it.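

In this assay, among these compounds, putting 6-chloro-2-fluoropyridin-3-yl in place of 4-cyano-2-fluorophenyl on a carbonyl carbon gives a number 49 percentage points higher from compound 1 to compound 3 (beyond the scatter), the first readable step. Among the compounds shown here, with the rest of the shared core unchanged, the maximal response clearly depends on the aromatic group at this position, and compound 3 at 78% shows that this core can reach a much larger maximal response than the single earlier number indicated. The data shown offer no measurement that accounts for this step.

The swap changes several features at once: the ring gains a hetero atom, the nitrile goes and a chlorine arrives, so this one step cannot assign the gain to any single feature. Still open, from the compounds shown here alone, is whether the chlorine of compound 3 can give way to an amine, a methoxy group or a plain hydrogen with the response kept, and whether a 4-chloro-2-fluorophenyl group on the same carbonyl carbon would behave like the pyridine of compound 3 or like the nitrile-bearing ring of compound 1.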